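A few compounds are considered here, and "the series" means these few. Any claim that something is new, unique, unknown or untested is made for them only; others in the source may bear on it.

Working notes on the series built on the core of compound 1 `C#CCSc1nnc(-c2cc(OC)c(OC)c(OC)c2)n1N1C(=O)c2ccccc2C1=O`, varied on the saturated chain carbon bound to a sulfur. In a functional assay on MKN-45 cells (Homo sapiens) for cytotoxicity, read by MTT assay, with a stated time of 48 h (on this read-out lower numbers stand for stronger inhibition and higher numbers for weaker inhibition), compound 1 gives only an assay limit, > 200000 nM. Compound 3 `COc1cc(-c2nnc(SCc3ccccc3)n2N2C(=O)c3ccccc3C2=O)cc(OC)c1OC` likewise gives only a limit in this assay, > 200000 nM. Compound 2 `COc1cc(-c2nnc(SCC(=O)c3ccc(Cl)cc3)n2N2C(=O)c3ccccc3C2=O)cc(OC)c1OC` gives 26600 nM in this assay. The steps of an at least 7.5-fold lower number from compound 1 to compound 2 (0.87 log units; beyond the scatter) and an at least 7.5-fold higher number from compound 2 to compound 3 (0.87 log units; beyond the scatter) both concern this position; note (the limit of > 200000 nM in this assay, at which 2 of the 3 values shown sit). Compound 4 `COc1cc(-c2nnc(SCC(=O)c3ccccc3)n2N2C(=O)c3ccccc3C2=O)cc(OC)c1OC` differs from compound 3 by benzoyl in place of phenyl on a saturated chain carbon bound to a sulfur, so it carries the carbonyl of compound 2 without the chloro substituent present there. Given that an at least 7.5-fold higher number from compound 2 to compound 3 (0.87 log units; beyond the scatter) was at least modest, a lower number is expected for compound 4, a step of about an at least 4.4-fold lower number from compound 3 to compound 4 (0.64 log units; beyond the scatter). Compound 4 is estimated at 45000 nM, range 15000 nM to 160000 nM.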

Compound 4, half-maximal inhibitory concentration: > 200000 nM
Compound 4 was reported as a limit; the forecaster's own chance of this, stated with the estimate: 25%; middle value at least 4.4-fold (0.64 log units) from the limit.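

Hydrogen in place of chloro on an aromatic carbon gives an at least 7.5-fold higher number from compound 2 to compound 4 (0.87 log units; beyond the scatter) in this assay. The chloro therefore separates compound 2 from compound 4, and the carbonyl without it gives no measurable value. The steps to compound 4 from compound 1 and compound 3 cannot be read, since each joins two limits: the limit of > 200000 nM in this assay, at which 3 of the 4 values shown sit.

Open, as far as these compounds go, is whether a bromo or an amine on that aromatic carbon would also give a measurable value. Also open, from the compounds shown here alone, is whether a longer chain on the sulfur would keep the value of compound 2.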